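The source may hold more compounds than are shown below. What is called first, only, known or untested is meant among the compounds shown, and "the series" means these compounds.

Going by the values given here, of the two compounds measured so far, compound 2 `O=C(N/N=C/c1ccccc1O)c1cc(-c2ccc(Cl)cc2)nn1Cc1ccccc1` carries the highest number: in a functional assay on A549 cells (Homo sapiens) for cytotoxicity, read by MTT assay, with a stated time of 48 h (a lower number here means a stronger inhibitor, a higher number a weaker inhibitor), compound 2 gives 4690 nM. Its nearest neighbour is compound 1 `O=C(N/N=C/c1ccccc1O)c1cc(-c2ccc(Cl)cc2)nn1Cc1ccc(Cl)nc1`, which in this assay gives 3660 nM, so that the step of a 1.3-fold higher number from compound 1 to compound 2 (0.11 log units; within the scatter) is one the repeated scatter of this assay could produce on its own.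

Compound 3 `CC(C)(C)c1ccc(Cn2nc(-c3ccc(Cl)cc3)cc2C(=O)N/N=C/c2ccccc2O)cc1` is the next compound to be measured. It differs from compound 2 in one place only: tert-butyl in place of hydrogen on an aromatic carbon, which in words is tert-butyl in place of hydrogen on an aromatic carbon. Among the compounds with values here, no measured step bears on this change; the only step available, from compound 1 to compound 2, concerns the group on the saturated chain carbon bound to the aromatic nitrogen, and it stayed within the scatter. With nothing pointing in either direction, the step of a 1.2-fold lower number from compound 2 to compound 3 (0.09 log units; within the scatter) is expected to stay within the scatter as well. The estimate for compound 3 in this assay is therefore 3800 nM, with a range from 1500 nM to 9500 nM.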

Compound 3, half-maximal inhibitory concentration: 3390 nM
Compound 3: the middle estimate sits 1.1-fold (0.05 log units) above what was measured, within the range that was stated.
By their numbers in this assay, from the lowest: compounds 3, 1 and 2 (each within the scatter of the next).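

In this assay, going by these compounds alone, the change from benzyl to 4-(tert-butyl)benzyl gives a 1.4-fold lower number from compound 2 to compound 3 (0.14 log units; within the scatter) and is the only measurement at this aromatic carbon, para to a large group. It shows that tert-butyl, with its 4 heavy atoms, can stand in place of hydrogen there without the number leaving the scatter. The second new step, a 1.1-fold lower number from compound 1 to compound 3 (0.03 log units; within the scatter), extends this to the third group on the saturated chain carbon bound to the aromatic nitrogen, so that 6-chloropyridin-3-yl, phenyl and 4-(tert-butyl)phenyl cannot be told apart in this assay, and nothing measured bears on why the change makes so little difference.

On these data alone, what remains open is whether a different group on this carbon, such as an amine, a carboxylic acid or a longer chain, would carry the number beyond the scatter, and whether tert-butyl would behave the same way on another carbon of that ring. The three compounds also share the rest of their structure, so they say nothing about how changes elsewhere on the shared core would read in this assay.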